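Amide variation on a shared core

A few compounds are considered here, and "the series" means these few. Any claim that something is new, unique, unknown or untested is made for them only; others in the source may bear on it.

Compound 1 `O=C(Nc1ccc(Br)cc1CN1C(=O)c2ccccc2C1=O)c1ccccn1` gives a limit of < 1000 nM in an assay on CHO cells for positive allosteric modulation of metabotropic glutamate receptor 5 (Rattus norvegicus), read by FLIPR; on this read-out higher numbers stand for an effect only at larger amounts of compound and lower numbers for an effect already at smaller amounts.
Compound 2 `O=C(Nc1ccc(Cl)cc1CN1C(=O)c2ccccc2C1=O)c1cccnn1` gives a limit of < 1000 nM in this assay.
Compound 3 `COc1cccc(C(=O)Nc2ccc(Cl)cc2CN2C(=O)c3ccccc3C2=O)c1` gives a limit of < 1000 nM in this assay.

Compound 2 thus stands only at a limit, not at a number; all three values sit at that same limit (the limit of < 1000 nM in this assay, at which 3 of the 3 values shown sit). Among the measured compounds shown here, the single measured step, a step that the two limits leave unreadable from compound 2 to compound 3, cannot be read between two limits. Compound 4 `O=C(Nc1ccc(Cl)cc1CN1C(=O)c2ccccc2C1=O)c1ncccc1O` differs from compound 2 by 3-hydroxypyridin-2-yl in place of pyridazin-3-yl on a carbonyl carbon. For the measured compounds named here, no measured step bears readably on this change, so no size of step in this assay can be expected from the data beyond the scatter, in either direction. Compound 4 is therefore expected at 300 nM, within 50 nM to 1000 nM. That estimate means an expected step that the limit leaves unreadable from compound 2 to compound 4.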

Compound 4, half-maximal effective concentration: < 1000 nM
Compound 4: no number, only a limit (the forecaster's own chance of this, stated with the estimate: 70%); the middle value is on the limit's open side.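

Compound 4 gives no readable step against compound 2 or compound 3, and every value remains a limit: the limit of < 1000 nM in this assay, at which 4 of the 4 values shown sit.

As far as these compounds go, whether the amide groups on the shared core differ at all in this assay stays open.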